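The source may report more compounds than this note shows. Statements on the series, on what has been measured and on what is new or still open speak of the compounds shown alone.

Compound 1 `Cc1ccc(NC(=O)Nc2cccc(Cl)c2)cc1NC(=O)c1cnoc1C`: > 30000 nM
Compound 2 `Cc1ccc(NC(=O)Nc2cc(Cl)cc(Cl)c2)cc1NC(=O)c1cnoc1C`: > 30000 nM

In a functional assay on U-937 cells (Homo sapiens) for antiproliferative activity, read by MTT assay, with a stated time of 24 h (a lower number here means a stronger inhibitor of growth, a higher number a weaker inhibitor of growth), compound 2 gives > 30000 nM. That figure is a limit of the assay and not a number, and the same holds for compound 1, so both sit at the limit of > 30000 nM in this assay, at which 2 of the 2 values shown sit.

Compound 3 `Cc1ccc(NC(=O)Nc2ccc(Cl)c(Cl)c2)cc1NC(=O)c1cnoc1C` has 3,4-dichlorophenyl in place of 3,5-dichlorophenyl on an amide-type nitrogen. Within the data shown here, the only measured step that bears on this is a step that the two limits leave unreadable from compound 1 to compound 2, so it offers no size to carry over. With no readable step to go on, no change beyond the usual scatter is expected in this assay.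

The expected step is a number no higher from compound 2 to compound 3 (the limit leaves the size open). Compound 3 is estimated at 30000 nM, with an expected range from 12000 nM to 60000 nM.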

Compound 3, concentration for 50% growth inhibition: 1890 nM
The estimate for compound 3 lay 16-fold (1.20 log units) above the measured number; the measured number lies below the stated range.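

In this assay, the same two chlorines arranged as 3,4-dichlorophenyl instead of 3,5-dichlorophenyl give an at least 15-fold lower number from compound 2 to compound 3 (1.20 log units; beyond the scatter), so the arrangement on this ring matters, not just the number of chlorines. A second chloro on the ring of compound 1 can therefore make a large difference, seen as an at least 15-fold lower number from compound 1 to compound 3 (1.20 log units; beyond the scatter). Compound 3 is the only compound shown with a readable number, as the others remain at a limit of the assay and not a number: the limit of > 30000 nM in this assay, at which 2 of the 3 values shown sit.

The compounds shown leave open whether a chloro is needed for this effect. Trifluoromethyl or methoxy in place of either chlorine of the 3,4-dichlorophenyl group could retain it or lose it.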